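The source may report more compounds than this note shows. Statements on the series, on what has been measured and on what is new or still open speak of the compounds shown alone.

Measured in an ADME assay on microsomes (Homo sapiens) for metabolic stability; a higher number here means that the compound lasts longer, a lower number that the compound disappears faster:

Compound 1 `O=C(c1cnco1)N1CCC(C(=O)N2N=CC[C@H]2c2ccccc2)CC1`: > 3 h
Compound 2 `CC(C)(C)C(=O)N1N=CCC1c1cocn1`: > 1.5 h

Compound 1 gives > 3 h as a limit and not a number. From the compounds shown here alone, for compound 2 the value > 1.5 h is likewise a limit and not a number, so its true half-life remains open. Compound 3 `CC(C)(C)C(=O)N1N=CCC1C1CCCC1` carries cyclopentyl in place of 1,3-oxazol-4-yl on a saturated ring carbon. Going by the values given here, no measured pair shows this change. A shorter half-life in this assay is expected, with an estimated step of an at least 1.6-fold lower number from compound 2 to compound 3 (0.22 log units; that floor lies within the scatter). For compound 3 the expected half-life is 0.9 h, with an estimated range of 0.3 h to 3 h.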

Compound 3, half-life: 0.0983 h
Compound 3: middle estimate off by 9.2-fold (0.96 log units), on the high side; measured number outside the range, below it.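

Going by these compounds alone, replacing 1,3-oxazol-4-yl with cyclopentyl on this saturated ring carbon gives the only readable step in this assay: an at least 15-fold lower number from compound 2 to compound 3 (1.18 log units; beyond the scatter). The two groups match in heavy-atom count, so the half-life at this position depends on more than the size of the group. From the compounds shown here alone, compound 2 gives > 1.5 h, which is a limit and not a number, so the full size of the step stays open.

Whether the step follows the loss of the ring's hetero atoms or the loss of its aromatic character remains unresolved. A tetrahydrofuranyl or a thienyl ring at this position would separate the two.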